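The source may report more compounds than this note shows. Statements on the series, on what has been measured and on what is new or still open speak of the compounds shown alone.

Compounds measured so far:
compound 1, `CCCC(CCC)Nc1ncnc2c1ncn2C1O[C@H](CO)[C@@H](O)[C@H]1O` — 3.3 nM
compound 2, `CCCn1c(=O)c2nc(-c3cccn3C)[nH]c2n(CCC)c1=O` — 140 nM
compound 3, `CCCn1c(=O)c2nc(-c3cc4ccccc4o3)[nH]c2n(CCC)c1=O` — > 100000 nM

In an assay on cell membranes for binding affinity to adenosine receptor A1 (Cavia porcellus), read by radioligand binding (on this read-out lower numbers stand for stronger inhibition and higher numbers for weaker inhibition), compound 1 gives 3.3 nM. Compound 2 gives 140 nM in this assay, the higher of the two numbers, with compound 1 lying well beyond the scatter on the stronger side. Compound 3 reaches only a limit of this assay, > 100000 nM, so no number is known for it; this is the limit described by the limit of > 100000 nM in this assay, at which 1 of the 3 values shown sits.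

Compound 4, `CCCn1c(=O)c2nc(CC3CC3)[nH]c2n(CCC)c1=O`, has not yet been measured. It keeps the shared core of compound 2 and differs in one place: cyclopropylmethyl in place of 1-methyl-1H-pyrrol-2-yl on an aromatic carbon. The group that leaves is aromatic and carries one hydrogen-bond acceptor; the group that enters is a small saturated ring on a short chain with none.

Among the measured compounds shown here, no measured pair in this set shows a step of exactly this kind, so the expectation rests on the position alone. A step of modest size is expected here, toward a somewhat lower number in this assay, though a result within the scatter of compound 2 would not surprise. The estimate for compound 4 is 80 nM, with a range from 15 nM to 400 nM, which means an expected step of a 1.8-fold lower number from compound 2 to compound 4 (0.24 log units; within the scatter).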

Compound 4, inhibition constant: 120 nM
Compound 4: the middle estimate sits 1.5-fold (0.18 log units) below what was measured; low and high end bracket the measured number.
By their numbers in this assay, from the lowest: compound 1; then compounds 4 and 2 (each within the scatter of the next). At a limit, above all of these: compound 3.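

In this assay, putting cyclopropylmethyl in the place of 1-methyl-1H-pyrrol-2-yl gives a 1.2-fold lower number from compound 2 to compound 4 (0.07 log units; within the scatter), so at this position, on an aromatic carbon between two ring nitrogen atoms, the aromatic group with its hydrogen-bond acceptor is not needed to keep this level of affinity: a small saturated ring on a short chain, with no acceptor, serves as well. Compound 3, which carries another group in this same place, stands at a limit of this assay, > 100000 nM, so the position does not take every group equally. Nothing shown explains why these groups behave as they do.

On these data alone, it remains open how much of the result depends on the three-membered ring itself, since a plain propyl chain, a longer chain or a cyclopropyl group set directly on the ring could each stay in this range or leave it. A group of a different kind in this place, such as an amine or a carboxylic acid, is also untested by the compounds shown here.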